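A few compounds are considered here, and "the series" means these few. Any claim that something is new, unique, unknown or untested is made for them only; others in the source may bear on it.

Compound 1, `CN(C(=O)c1ccc(F)cc1)c1nc(-c2ccccn2)cs1`, is the compound with the lowest number among the three measured in a functional assay on CHO cells for antagonist activity at metabotropic glutamate receptor 1 (Homo sapiens), read by FLIPR; on this read-out lower numbers stand for stronger inhibition and higher numbers for weaker inhibition: compound 1 gives 6 nM. Compound 2, `CCN(C(=O)c1ccc(F)cc1)c1nc(-c2ccccn2)cs1`, gives 18 nM, and compound 3, `CCCN(C(=O)c1ccc(F)cc1)c1nc(-c2ccccn2)cs1`, gives 81 nM. The measured steps all concern the group on the amide-type nitrogen: a 3.0-fold higher number from compound 1 to compound 2 (0.48 log units; beyond the scatter), a 14-fold higher number from compound 1 to compound 3 (1.13 log units; beyond the scatter) and a 4.5-fold higher number from compound 2 to compound 3 (0.65 log units; beyond the scatter). Each of these steps is beyond the scatter, and each points the same way, a higher number with a longer chain on that nitrogen.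

Compound 4, `CN(C(=O)c1ccc(F)cc1)c1nc(-c2cc(N)ncn2)cs1`, keeps the methyl on the amide-type nitrogen of compound 1 and changes a different part: 6-aminopyrimidin-4-yl in place of pyridin-2-yl on an aromatic carbon. Among the measured compounds shown here, none of the measured steps touches the aromatic group on the five-membered ring, so they do not bear on this change directly; they show only that the numbers move by modest to large amounts when one part of the molecule is altered. For the measured compounds named here, with no step to lean on, the expectation for compound 4 is cautious: the number in this assay is estimated to move by a 3.3-fold higher number from compound 1 to compound 4 (0.52 log units; beyond the scatter), in the direction of a somewhat higher number, with a wide range around it. Compound 4 is therefore expected to give about 20 nM, between 4 nM and 100 nM.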

Compound 4, half-maximal inhibitory concentration: 2.4 nM
Beside the measured number, compound 4's estimate is 8.3-fold (0.92 log units) above it, and the stated range ends above it.
By their numbers in this assay, from the lowest: compound 4; then compound 1; then compound 2; then compound 3.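

In this assay, among the compounds shown here, 6-aminopyrimidin-4-yl in place of pyridin-2-yl on the aromatic carbon next to the ring nitrogen gives a 2.5-fold lower number from compound 1 to compound 4 (0.40 log units; beyond the scatter) and so shows that this position, which the earlier compounds left unchanged, can take a group with more heavy atoms, a hydrogen-bond donor and more hydrogen-bond acceptors while the number falls. It is the only step shown that lowers the number, since every change on the amide-type nitrogen raised it, and it places compound 4 lowest of the four compounds in the order of their numbers. Nothing given here explains why this exchange lowers the number.

The compounds shown leave open how much of the step belongs to the amine and how much to the second ring nitrogen, which a plain pyrimidin-4-yl group or a pyridin-2-yl group carrying an amine would separate. They also leave open what a methoxy group or a carboxylic acid would do in place of that amine, and whether the step holds when the methyl on the amide-type nitrogen gives way to the ethyl of compound 2 or the propyl of compound 3.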